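Cytotoxicity on Raji cells: aldehyde to alcohol step

A few compounds are considered here, and "the series" means these few. Any claim that something is new, unique, unknown or untested is made for them only; others in the source may bear on it.

Measured so far, in an ADME assay on Raji cells (Homo sapiens) for cytotoxicity, read by CellTiter-Glo and resazurin assay, with a stated time of 72 h; on this read-out higher numbers stand for an effect only at larger amounts of compound and lower numbers for an effect already at smaller amounts:
compound 1 `CCOC(=O)CCCCCOc1cccc(CN(C(=O)c2ccc(-c3cccc(N(C)C)c3)cc2)C(C)C)c1` gives > 26000 nM, which is a limit of the assay.
compound 2 `CCOC(=O)CCCCCOc1cccc(CN(C(=O)c2ccc(-c3cccnc3)cc2)C(C)C)c1` gives > 26000 nM, which is a limit of the assay.
compound 3 `CCOC(=O)CCCCCOc1ccc(C=O)cc1` gives > 26000 nM, which is a limit of the assay.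

Compound 3 thus stands at the limit, and no number is known for it. The same holds for the whole set: the limit of > 26000 nM in this assay, at which 3 of the 3 values shown sit. Within the data shown here, the one step between measured compounds, a step that the two limits leave unreadable from compound 1 to compound 2, is therefore not readable either, and it concerns a different part of the structure than the step now at hand.

Compound 4 `CCOC(=O)CCCCCOc1ccc(CO)cc1` differs from compound 3 only in this: hydroxymethyl in place of formyl on an aromatic carbon. No measured step bears on this change, and nothing in the set gives a cause for any change. With every value sitting at the limit, the expectation for compound 4 in this assay is a step that the limit leaves unreadable from compound 3 to compound 4, that is, none readable, and compound 4 is expected again to reach only the limit rather than a number.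

Estimated value for compound 4 in this assay: 50000 nM, within 26000 nM to 200000 nM.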

Compound 4, half-maximal effective concentration: > 27100 nM
Compound 4: no number, only a limit; the forecaster's own chance of this, stated with the estimate: 90%; the middle value does not contradict the limit.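

Compound 3 and compound 4 both give only limits in this assay, so no step can be read between them. The compounds shown leave open whether hydroxymethyl in place of formyl changes the read-out at all, and at what concentration any of them would give a number in this assay.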